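Swapping an Ether Oxygen for an Amine Nitrogen

The compounds below may be only part of what the source reports. "The series", "measured", "known", "first", "only" and "open" are said of these compounds alone.

Three related compounds have been tested in a functional assay on ileum for inhibition of histamine H1 receptor (Cavia porcellus); a higher number here means a weaker inhibitor, a lower number a stronger inhibitor. Compound 1 `CCCCOCCn1c(N2CCCN(C)CC2)nc2ccccc21` gives 10 nM, compound 2 `CN1CCN(c2nc3ccccc3n2CCOc2ccccc2)CC1` gives 6.9 nM, and compound 3 `CCOCCn1c(N2CCN(C)CC2)nc2ccccc21` gives 10 nM. Going by the values given here, compound 3 thus sits level with compound 1, the two together at the top of the three numbers, and the only measured step, a 1.4-fold higher number from compound 2 to compound 3 (0.16 log units; within the scatter), stays within the scatter. Compound 4 `CCNCCn1c(N2CCN(C)CC2)nc2ccccc21` differs from compound 3 by ethylamino in place of ethoxy on a saturated chain carbon, two bonds along the chain from an aromatic nitrogen. Among the compounds with values here, no measured step replaces this oxygen itself; the one step on record, a 1.4-fold higher number from compound 2 to compound 3 (0.16 log units; within the scatter), only altered what hangs from the oxygen and barely moved the number. Compound 4 is therefore expected to shift by about a 1.5-fold higher number from compound 3 to compound 4 (0.18 log units; within the scatter), with no clear direction. The estimate for compound 4 is 15 nM, within a range from 4 nM to 60 nM.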

Compound 4, half-maximal inhibitory concentration: 290 nM
The estimate for compound 4 lay 19-fold (1.29 log units) below the measured number; the measured number lies above the stated range.
By their numbers in this assay, from the lowest: compounds 2, 1 and 3 (each within the scatter of the next); then compound 4.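

In these compounds, the atom joining the side group to the chain counts for far more than the group on that atom: ethylamino in place of ethoxy gives a 29-fold higher number from compound 3 to compound 4 (1.46 log units; beyond the scatter), and ethylamino in place of phenoxy gives a 42-fold higher number from compound 2 to compound 4 (1.62 log units; beyond the scatter). Both exchanges add a hydrogen-bond donor and leave the number of heavy atoms in the group that changes from ethoxy to ethylamino the same. Nothing shown explains this loss of strength. The compounds shown leave open how dimethylamino, whose nitrogen carries no hydrogen, or ethylthio would fare at this place.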